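Removing Two Methoxy Groups: From Compound 3 to Compound 4

A few compounds are considered here, and "the series" means these few. Any claim that something is new, unique, unknown or untested is made for them only; others in the source may bear on it.

Compound 1, `COc1cccc(/C=C/C[C@@H]2C[C@@H]([C@@H](O)c3ccc(OC)c(OC)c3)CO[C@H]2c2ccc(OC)c(OC)c2)c1`: 16400 nM
Compound 2, `COc1ccc([C@H](O)[C@H]2CO[C@@H](c3ccc(OC)c(OC)c3)[C@H](C/C=C/c3ccc(OC)c(OC)c3)C2)cc1`: 32200 nM
Compound 3, `COc1ccc(/C=C/C[C@@H]2C[C@@H]([C@@H](O)c3ccc(OC)c(OC)c3)CO[C@H]2c2ccc(OC)c(OC)c2)cc1OC`: 30600 nM

Of the compounds shown here, three have been measured in a functional assay on HeLa cells (Homo sapiens) for cytotoxicity, read by WST assay, with a stated time of 48 h; a lower number here means a stronger inhibitor, a higher number a weaker inhibitor. Compound 3 holds the second highest of the three numbers; its nearest neighbour is compound 2, and compound 1 lies furthest away, though both steps of a 1.9-fold higher number from compound 1 to compound 3 (0.27 log units; within the scatter) and a 1.1-fold lower number from compound 2 to compound 3 (0.02 log units; within the scatter) stay within the scatter. Each of those two steps added a methoxy in place of hydrogen on an aromatic carbon, on a different aryl group of the shared core, and neither moved the number beyond the scatter.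

Compound 4, `COc1ccc(/C=C/C[C@@H]2C[C@@H]([C@@H](O)c3ccc(OC)c(OC)c3)CO[C@H]2c2ccccc2)cc1OC`, is not yet measured. It differs from compound 3 in one place: phenyl in place of 3,4-dimethoxyphenyl on a saturated ring carbon. Both measured steps bear on this change, since both concern methoxy groups on an aromatic ring, and both were small. For the measured compounds named here, the removal of two methoxy groups at once is a larger change than either, but there is no measured step that shows such a change moving the number beyond the scatter. For compound 4 the expected step is therefore a 1.0-fold lower number from compound 3 to compound 4 (0.01 log units; within the scatter), that is, none beyond the scatter. Compound 4 is estimated at 30000 nM, with a range from 12000 nM to 75000 nM.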

Compound 4, half-maximal inhibitory concentration: 16100 nM
For compound 4 the middle estimate is 1.9-fold (0.27 log units) above the measured one; low and high end bracket the measured number.
By their numbers in this assay, from the lowest: compounds 4, 1, 3 and 2 (each within the scatter of the next).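

In this assay, phenyl in place of 3,4-dimethoxyphenyl on the saturated ring carbon next to the ring oxygen gives a 1.9-fold lower number from compound 3 to compound 4 (0.28 log units; within the scatter). For the compounds shown here, compounds 1, 2 and 3 all carry 3,4-dimethoxyphenyl at this place, so compound 4 gives the first reading of it, and it shows that this aryl group can lose both methoxy groups at once while the number stays within the scatter. Nothing available explains this result or shows what the two methoxy groups do at this place.

As far as these compounds go, the aromatic ring itself is kept in all four compounds, so whether it is needed here remains open. Also open, from the compounds shown here alone, is what a methyl group, or a phenyl carrying an amine or a carboxylic acid, would give at this place.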